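Changing the aryl group on the sulfonamide nitrogen

The source may report more compounds than this note shows. Statements on the series, on what has been measured and on what is new or still open speak of the compounds shown alone.

In a functional assay on MCF7 cells (Homo sapiens) for antiproliferative activity, read by sulforhodamine B assay, with a stated time of 48 h (a lower number here means a stronger inhibitor, a higher number a weaker inhibitor), compound 1 (`CCc1ccccc1NS(=O)(=O)c1ccc(N2CCNC2=O)cc1`) gives 350 nM, compound 2 (`CCc1cccc(NS(=O)(=O)c2ccc(N3CCNC3=O)cc2)c1`) gives 130 nM and compound 3 (`Cc1cccc(NS(=O)(=O)c2ccc(N3CCNC3=O)cc2)c1C`) gives 230 nM. Compound 3 stands within the scatter of both other compounds, as the two steps show: a 1.5-fold lower number from compound 1 to compound 3 (0.18 log units; within the scatter), and a 1.8-fold higher number from compound 2 to compound 3 (0.25 log units; within the scatter). Among the compounds with values here, the only step beyond the scatter is a 2.7-fold lower number from compound 1 to compound 2 (0.43 log units; beyond the scatter), with 3-ethylphenyl in place of 2-ethylphenyl on a sulfonamide nitrogen.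

Compound 4 (`COc1ccc(NS(=O)(=O)c2ccc(N3CCNC3=O)cc2)cc1`) carries 4-methoxyphenyl in place of 2,3-dimethylphenyl on a sulfonamide nitrogen. Within the data shown here, no measured compound carries a methoxy group, so no measured step tests this group directly. The three measured steps bear on it only as changes at the same place, and they give no direction for the new group. The largest of them is modest, so a step of that size would be a large outcome here, and no step beyond the scatter is expected in this assay. The estimate corresponds to a 1.1-fold higher number from compound 3 to compound 4 (0.04 log units; within the scatter), an expected step that stays small. The estimated value for compound 4 is 250 nM, with an expected range of 90 nM to 700 nM.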

Compound 4, half-maximal inhibitory concentration: > 1000 nM
Compound 4 ended at the assay's limit; the forecaster's own chance of this, stated with the estimate: 3%; at least 4.0-fold (0.60 log units) between middle value and limit.
By their numbers in this assay, from the lowest: compounds 2, 3 and 1 (each within the scatter of the next, the first and the last beyond it). At a limit, above all of these: compound 4.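

In this assay the value of compound 4 is a limit and not a number: (the limit of > 1000 nM in this assay, at which 1 of the 4 values shown sits).

Even read from that limit, 4-methoxyphenyl on a sulfonamide nitrogen separates from all three earlier aryl groups, with each step beyond the scatter: (an at least 4.3-fold higher number from compound 3 to compound 4 (0.63 log units; beyond the scatter)), (an at least 7.6-fold higher number from compound 2 to compound 4 (0.88 log units; beyond the scatter)) and (an at least 2.8-fold higher number from compound 1 to compound 4 (0.45 log units; beyond the scatter)). Within the data shown here, compound 4 is therefore the weakest of the four in this assay, and the earlier compounds, which held only alkyl-substituted phenyl groups, did not show that a change at this place could reach this size. Among these compounds, this is also the first change here that brings in oxygen and a hydrogen-bond acceptor, but the substitution pattern on the phenyl ring changes with it, so the step cannot be assigned to either one.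

The compounds shown leave open whether the methoxy group itself or its placement accounts for the loss, and how far compound 4 actually lies past the limit. They also leave open how a halogen such as chlorine, an amine or a carboxylic acid on the phenyl ring would read at this place.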